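The source may report more compounds than this note shows. Statements on the series, on what has been measured and on what is new or still open speak of the compounds shown alone.

Measured compounds in a functional assay on L02 cells (Homo sapiens) for inhibition, read by Griess assay, with stated times of 1 h and 24 h; on this read-out lower numbers stand for stronger inhibition and higher numbers for weaker inhibition:
Compound 1 `CNc1nc(/C=C/c2cc(OC)c(OC)c(OC)c2)nc2ccsc12` — compound 1 gives > 1000000 nM, a limit of the assay.
Compound 2 `COc1cc(/C=C/c2nc(Nc3ccc(O)cc3)c3sccc3n2)cc(OC)c1OC` — compound 2 gives > 1000000 nM, a limit of the assay.
Compound 3 `COc1cc(/C=C/c2nc(NCc3ccc(Cl)cc3)c3sccc3n2)cc(OC)c1OC` — compound 3 gives > 1000000 nM, a limit of the assay.

All three values sit at the same point, the limit (the limit of > 1000000 nM in this assay, at which 3 of the 3 values shown sit). None of the steps among them can be read: a step that the two limits leave unreadable from compound 1 to compound 2; a step that the two limits leave unreadable from compound 1 to compound 3; a step that the two limits leave unreadable from compound 2 to compound 3. Among the compounds with values here, compound 3 therefore stands at the limit of this assay, with no number to place it against the other two, and no step gives a size or a direction that could carry over.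

Compound 4 `COc1cc(/C=C/c2nc(OCc3ccccc3)c3sccc3n2)cc(OC)c1OC` is not yet measured. It differs from compound 3 in one place: benzyloxy in place of (4-chlorobenzyl)amino on an aromatic carbon. Within the data shown here, no measured step bears on this change in a readable way; the three steps only show that a methylamino, a 4-hydroxyphenylamino and a 4-chlorobenzylamino group at this position all leave the value at the limit. Compound 4 is therefore expected to stay at the limit too, with the step from compound 3 to compound 4 estimated as a number no higher from compound 3 to compound 4 (the limit leaves the size open). The estimate for compound 4 in this assay is 1000000 nM, expected to fall between 300000 nM and 3000000 nM.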

Compound 4, half-maximal inhibitory concentration: > 1000000 nM
Compound 4 ended at the assay's limit; the forecaster's own chance of this, stated with the estimate: 80%; the middle value sits exactly at the limit.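

No step from compounds 1, 2 or 3 to compound 4 can be read in this assay, since all four compounds stand at the same limit: the limit of > 1000000 nM in this assay, at which 4 of the 4 values shown sit.

The compounds shown leave open whether any group in this place on the shared core gives a measurable value in this assay, and how far compounds 1, 2, 3 and 4 differ.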